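This account rests on a few compounds, and the source may have more. Where it says the series, first, only, none or still open, it means among the compounds named here.

In an ADME assay on BV-2 cells (Mus musculus) for cytotoxicity, read by MTT assay, with a stated time of 48 h, tested at 20 uM (a lower number here means a stronger effect, a higher number a weaker effect of the compound at the concentration tested), compound 1 `Cc1ccc(S(=O)(=O)n2cc(/C=N\c3ccc(N4CCOCC4=O)cc3)c3ccccc32)cc1` gives 56.7%, compound 2 `O=C1COCCN1c1ccc(/N=C\c2cn(C(=O)c3ccccc3)c3ccccc23)cc1` gives 85.1%, and compound 3 `O=C1COCCN1c1ccc(/N=C\c2cn(C(=O)c3ccc(Cl)cc3)c3ccccc23)cc1` gives 99%. Compound 2 thus stands second highest of the three numbers, with the step of a number 13.9 percentage points higher from compound 2 to compound 3 (beyond the scatter) above it and the step of a number 28.4 percentage points higher from compound 1 to compound 2 (beyond the scatter) beneath it. Compound 4 `O=C1COCCN1c1ccc(/N=C\c2cn(Cc3ccccc3)c3ccccc23)cc1` differs from compound 2 by benzyl in place of benzoyl on an aromatic nitrogen. The measured steps that alter the group on this aromatic nitrogen are a number 28.4 percentage points higher from compound 1 to compound 2 (beyond the scatter) and a number 42.3 percentage points higher from compound 1 to compound 3 (beyond the scatter), both moving the number upward; the step of a number 13.9 percentage points higher from compound 2 to compound 3 (beyond the scatter) changes a different place. For the measured compounds named here, no measured step exchanges benzoyl for benzyl, so the direction is uncertain and a modest lowering is expected, namely a number 13.1 percentage points lower from compound 2 to compound 4 (beyond the scatter). Compound 4 is therefore estimated at 72% in this assay, with a range from 50% to 95%.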

Compound 4, a percentage reported as activity, at one concentration (the size of the read-out at that concentration, not a potency): 87.8%
Beside the measured number, compound 4's estimate is 15.8 percentage points below it; low and high end bracket the measured number.
By their numbers in this assay, from the lowest: compound 1; then compounds 2 and 4 (each within the scatter of the next); then compound 3.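

In this assay, benzyl in place of benzoyl on the aromatic nitrogen, which removes the carbonyl, leaves the read-out within the scatter (a number 2.7 percentage points higher from compound 2 to compound 4 (within the scatter)). Benzyl is still clearly separated from the two other groups at this position (a number 31.1 percentage points higher from compound 1 to compound 4 (beyond the scatter); a number 11.2 percentage points lower from compound 3 to compound 4 (beyond the scatter)), so a carbonyl on this nitrogen is not needed to keep the number well clear of compound 1. Nothing available here gives a reason for these steps. Open, on these data alone, is how a longer chain, an amine or a carboxylic acid would read on this aromatic nitrogen, and whether chloro on the benzyl ring would raise the number as it does on benzoyl.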